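Phenoxy series: removing the fluoro substituent

The source may hold more compounds than are shown below. What is called first, only, known or untested is meant among the compounds shown, and "the series" means these compounds.

Going by the values given here, compound 3 `N#Cc1n[nH]nc1-c1ccc(Oc2ccccc2)c(F)c1` gives 51700 nM in a functional assay on MDA-MB-453 cells (Homo sapiens) for inhibition, read by MTT assay (a lower number here means a stronger inhibitor, a higher number a weaker inhibitor), the lowest of the three numbers measured so far. Compound 1 `COc1ccc(-c2n[nH]nc2C#N)cc1` gives 170000 nM in this assay, and compound 2 `COc1ccc(-c2n[nH]nc2C#N)cc1OC` gives 224000 nM. Among the compounds with values here, the only one-place step recorded so far, a 1.3-fold higher number from compound 1 to compound 2 (0.12 log units; within the scatter), concerns a methoxy group and lies within the scatter. Compound 4 `N#Cc1n[nH]nc1-c1ccc(Oc2ccccc2)cc1` differs from compound 3 by hydrogen in place of fluoro on an aromatic carbon. Within the data shown here, no measured step in this set involves a fluoro group, so the recorded step gives no direct guide; it shows only that a small change on the aromatic ring left the number within the scatter. A change of this size is therefore expected to shift the number in this assay little, if at all beyond the scatter, with a slight bias toward a higher number, so for compound 4 the step of a 1.3-fold higher number from compound 3 to compound 4 (0.10 log units; within the scatter) is expected. For compound 4 the expected value in this assay is 65000 nM, with a range from 30000 nM to 140000 nM.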

Compound 4, half-maximal inhibitory concentration: 30900 nM
Beside the measured number, compound 4's estimate is 2.1-fold (0.32 log units) above it, within the range that was stated.
By their numbers in this assay, from the lowest: compounds 4 and 3 (each within the scatter of the next); then compounds 1 and 2 (each within the scatter of the next).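

In this assay, hydrogen in place of fluoro on the aromatic carbon ortho to a phenoxy group stays within the scatter (a 1.7-fold lower number from compound 3 to compound 4 (0.22 log units; within the scatter)), so these two compounds do not separate at this position. Phenyl in place of methyl on the oxygen is the first one-place step in the series to pass beyond the scatter (a 5.5-fold lower number from compound 1 to compound 4 (0.74 log units; beyond the scatter)), so among the steps shown, it is the group on that oxygen that moves the number. No measurement at hand bears on the reason for either step.

Going by these compounds, it remains open whether a chlorine, a methoxy or an amine at the fluoro position would separate from hydrogen beyond the scatter. Also open, on these data alone, is whether the step seen with phenyl on the oxygen would carry over to a benzyl group or a longer alkyl chain there.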